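Chalcone series: bromo added para on the phenyl ring

The source may report more compounds than this note shows. Statements on the series, on what has been measured and on what is new or still open speak of the compounds shown alone.

Compound 2 `COc1cc(OC)c(C(=O)/C=C/c2ccccc2)c(OC)c1` gives 24% in a functional assay on PC-3 cells (Homo sapiens), read by fluorescence and BrdU incorporation, with a stated time of 48 h, tested at 10 uM (on this read-out higher numbers stand for a weaker effect at the one concentration tested and lower numbers for a stronger effect), the second highest of the three numbers in hand. Within the data shown here, compound 1 `COc1cccc(/C=C/C(=O)c2c(OC)cc(OC)cc2OC)c1` gives 23%; the single change a number 1 percentage points higher from compound 1 to compound 2 (within the scatter). Compound 3 `COc1cc(O)c(C(=O)/C=C/c2ccccc2OC)c(OC)c1` gives 36%, a higher number than compound 2, beyond the scatter, but it differs from compound 2 in more than one place, so only the two values themselves can be compared.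

Compound 4 `COc1cc(OC)c(C(=O)/C=C/c2ccc(Br)cc2)c(OC)c1` differs from compound 2 by bromo in place of hydrogen on an aromatic carbon. Among the measured compounds shown here, none of the measured steps touches this ring position: the only single-point step is the one from compound 1 to compound 2, which removed a methoxy on the same ring and stayed within the scatter. That step gives no size for a bromo entering para to a large group, so no step beyond the scatter is expected in this assay in either direction. Compound 4 is therefore estimated at 25%, with a range from 10% to 45%, which means an expected step of a number 1 percentage points higher from compound 2 to compound 4 (within the scatter).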

Compound 4, a percentage reported as activity, at one concentration (the size of the read-out at that concentration, not a potency): 35%
Estimate against measurement, compound 4: 10 percentage points below; the range from low to high includes it.
By their numbers in this assay, from the lowest: compounds 1 and 2 (each within the scatter of the next); then compounds 4 and 3 (each within the scatter of the next).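

Bromo in place of hydrogen, para to a large group, gives a number 11 percentage points higher from compound 2 to compound 4 (beyond the scatter) in this assay, so this is the first single-place change in the series to move the read-out beyond the scatter, towards a weaker effect at the one concentration tested. Exchanging 3-methoxyphenyl for 4-bromophenyl gives a number 12 percentage points higher from compound 1 to compound 4 (beyond the scatter), a step of the same direction, whereas the loss of the methoxy alone gave a number 1 percentage points higher from compound 1 to compound 2 (within the scatter). No measurement in hand accounts for the shift.

Open, as far as these compounds go, is whether the step belongs to bromo itself or to any group entering at this position, which an amine or a carboxylic acid in the same place would help to separate. Also open, from the compounds shown here alone, is whether the same change on the core of compound 3 would give a step of similar size.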